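A Fluoro Step on the Biaryl Tail, Tested Twice

The source may hold more compounds than are shown below. What is called first, only, known or untested is meant among the compounds shown, and "the series" means these compounds.

Measured compounds:
Compound 1, `O=S(=O)(Nc1ccc(CO)c(CO)c1)c1ccc(-c2ccc(F)cc2)cc1`: 1000 nM
Compound 2, `O=S(=O)(Nc1ccc(CO)c(CO)c1)c1ccc(-c2ccc(F)cc2F)cc1`: 150 nM
Compound 3, `O=S(=O)(Nc1cccc(CO)c1)c1ccc(-c2ccc(Br)cc2)cc1`: 2500 nM

The three measured compounds were examined in a functional assay on J774 cells (Mus musculus) for cytotoxicity, read by resazurin assay, with a stated time of 72 h; on this read-out lower numbers stand for stronger inhibition and higher numbers for weaker inhibition. Compound 1 gives 1000 nM in this assay, and compound 2 gives 150 nM. The two differ only in fluoro in place of hydrogen on an aromatic carbon, and this change made the step of a 6.7-fold lower number from compound 1 to compound 2 (0.82 log units; beyond the scatter). Compound 3 gives 2500 nM, the highest number of the three. How the core of compound 3 differs from the core of compound 1 is not broken down here.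

Compound 4, `O=S(=O)(Nc1cccc(CO)c1)c1ccc(-c2ccc(Br)cc2F)cc1`, has not yet been measured. It differs from compound 3 in fluoro in place of hydrogen on an aromatic carbon. For the measured compounds named here, this is the same kind of change as the one from compound 1 to compound 2, but not the same: in compound 2 the entering fluoro sits meta to a fluoro group, whereas in compound 4 it sits meta to a bromo group, and the shared core is a different one. Going by the values given here, because the earlier step was a 6.7-fold lower number from compound 1 to compound 2 (0.82 log units; beyond the scatter), a lower number is expected for compound 4 as well, though with only one precedent on a different core the expected step from compound 3 to compound 4 is put more cautiously at a 2.5-fold lower number from compound 3 to compound 4 (0.40 log units; beyond the scatter). Compound 4 is therefore estimated to give 1000 nM in this assay, with an expected range from 400 nM to 2500 nM.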

Compound 4, half-maximal inhibitory concentration: 1000 nM
Compound 4: middle estimate and measured number agree at the digits printed; low and high end bracket the measured number.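

In this assay, fluoro in place of hydrogen on an aromatic carbon again gave a lower number, the new step being a 2.5-fold lower number from compound 3 to compound 4 (0.40 log units; beyond the scatter), so the direction of the change held on both cores shown. The size of the step did not carry over unchanged, and the two steps stand clearly apart: the same change on two cores in this assay, a 6.7-fold lower number (0.82 log units; beyond the scatter) from compound 1 to compound 2 and a 2.5-fold lower number (0.40 log units; beyond the scatter) from compound 3 to compound 4, 2.7-fold (0.43 log units) apart, beyond the scatter of two such steps What this does not show is which difference goes with the smaller step, since the two pairs differ both in the shared core and in the halogen already present, a fluoro group in compound 2 and a bromo group in compound 4, and two pairs cannot separate these or predict the size of the step on any further core.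

As far as these compounds go, it remains open whether the same change would give a similar step with a methyl group or a nitrile in place of the bromo group, or with a carboxylic acid or an amine in place of a hydroxymethyl group on the core. From the compounds shown here alone, it is also open how a chloro group entering at the same place would compare with fluoro in this assay, and how a bromo group would behave on the core of compound 1.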